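Ester to thiazolyl amide on the core carbonyl: notes

The compounds below may be only part of what the source reports. "The series", "measured", "known", "first", "only" and "open" are said of these compounds alone.

Compound 1, `CCOC(=O)c1c(O)c2cccnc2n(-c2ccccc2)c1=O`: 15.5%
Compound 2, `O=C(Nc1ccccc1)c1c(O)c2cccnc2n(-c2ccccc2)c1=O`: -15%
Compound 3, `COc1cccc(NC(=O)c2c(O)c3cccnc3n(-c3ccccc3)c2=O)c1`: 20.7%

All three numbers come from a functional assay on the whole organism for inhibition, with Rattus norvegicus as the target, read by cytopathic effect and paw edema, at a dose of 100 mg/kg by the oral route; a higher number here means more inhibition at the dose given (going by the name of the read-out), a lower number less inhibition. Compound 1 stands second highest of the three; compound 3 lies nearest, a gap within the scatter, while compound 2 is furthest and sits lower beyond the scatter. Compound 4, `O=C(Nc1nccs1)c1c(O)c2cccnc2n(-c2ccccc2)c1=O`, has no number yet in this assay. It differs from compound 1 in one place: (1,3-thiazol-2-yl)amino in place of ethoxy on a carbonyl carbon.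

Two measured steps start from the same carbonyl carbon of compound 1. Anilino in place of ethoxy gave a number 30.5 percentage points lower from compound 1 to compound 2 (beyond the scatter), whereas (3-methoxyphenyl)amino in place of ethoxy gave a number 5.2 percentage points higher from compound 1 to compound 3 (within the scatter). The two amides are themselves separated by a number 35.7 percentage points higher from compound 2 to compound 3 (beyond the scatter), so the amides already seen spread widely and no single direction follows from replacing the ester by an amide. Compound 4 is a third amide on this carbonyl carbon, with a five-membered aromatic ring in place of the benzene rings of the others, and nothing measured speaks to that ring. A step of about a number 5.5 percentage points lower from compound 1 to compound 4 (within the scatter) is therefore expected for compound 4, which is no step beyond the scatter, but with a wide margin either way. The estimate for compound 4 is 10%, with a range from -20% to 35%.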

Compound 4, a percentage reported as inhibition, in the whole organism at one dose (the size of the read-out at that dose, not a potency): 2.5%
Beside the measured number, compound 4's estimate is 7.5 percentage points above it; the measured number falls inside the stated range.
By their numbers in this assay, from the lowest: compound 2; then compound 4; then compounds 1 and 3 (each within the scatter of the next).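

In this assay, (1,3-thiazol-2-yl)amino in place of ethoxy on the carbonyl carbon gives a number 13 percentage points lower from compound 1 to compound 4 (beyond the scatter), so a third amide now sits apart from the ester, as the anilino amide does, while the (3-methoxyphenyl)amino amide remains the one exception, within the scatter of the ester. With the amide held constant, the group on the amide-type nitrogen still moves the number in both directions: 1,3-thiazol-2-yl in place of phenyl gives a number 17.5 percentage points higher from compound 2 to compound 4 (beyond the scatter), and 1,3-thiazol-2-yl in place of 3-methoxyphenyl gives a number 18.2 percentage points lower from compound 3 to compound 4 (beyond the scatter), which places the five-membered ring inside the span of the two benzene-ring amides rather than outside it. Nothing available accounts for these differences.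

How a carboxylic acid or a simple methylamino group would read on this carbonyl carbon remains open, since all the amides shown carry an aromatic ring on the nitrogen. Also open, going by these compounds, is whether pyridin-2-yl on the amide-type nitrogen would read like phenyl or like 1,3-thiazol-2-yl, and whether a methoxy group on the five-membered ring would raise the number as it does on the benzene ring.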